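Series notes: phenyl in place of ethyl, compound 3

The source may report more compounds than this note shows. Statements on the series, on what has been measured and on what is new or still open speak of the compounds shown alone.

Compound 1 `Cc1nnc(-c2nsc3ccccc23)o1` and compound 2 `CCc1nnc(-c2nsc3ccccc23)o1` share one core and differ in one place. Within the data shown here, in a functional assay on the whole organism for inhibition, with Rattus norvegicus as the target, with a stated time of 3.5 h, at a dose of 100 mg/kg by the intraperitoneal route (a lower number here means less inhibition, a higher number more inhibition at the dose given (going by the name of the read-out)), compound 1 gives 42%, while compound 2 gives 10%, the lowest of the two numbers so far; the step of a number 32 percentage points lower from compound 1 to compound 2 (beyond the scatter) went with methyl in place of hydrogen on a saturated chain carbon bound to an aromatic carbon. Compound 3 `c1ccc(-c2nnc(-c3nsc4ccccc34)o2)cc1` is not yet measured and differs from compound 2 by phenyl in place of ethyl on an aromatic carbon. Among the measured compounds shown here, only one measured step bears on this change, and it is of another kind: growing the group at this position lowered the read-out well beyond the scatter. Whether phenyl behaves like ethyl is not shown, so the expectation rests on a low starting point. Compound 3 is expected to stay low, with an estimated step of a number 5 percentage points higher from compound 2 to compound 3 (within the scatter) that need not exceed the scatter. The estimate for compound 3 in this assay is 15%, within 0% to 45%.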

Compound 3, a percentage reported as inhibition, in the whole organism at one dose (the size of the read-out at that dose, not a potency): 48%
Compound 3: middle estimate off by 33 percentage points, on the low side; the measured number lies above the stated range.
By their numbers in this assay, from the lowest: compound 2; then compounds 1 and 3 (each within the scatter of the next).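

Growing the group on this aromatic carbon does not lower the read-out in this assay in any simple way: the step of a number 38 percentage points higher from compound 2 to compound 3 (beyond the scatter) shows that the fall seen with ethyl does not carry over to phenyl, a larger group that also brings a six-membered aromatic ring. With the step of a number 6 percentage points higher from compound 1 to compound 3 (within the scatter), phenyl and methyl cannot be told apart here, so among these three compounds only compound 2 stands apart, and the low number goes with ethyl rather than with group size as such. Nothing at hand explains why ethyl stands apart from methyl and phenyl.

Open, going by these compounds, is whether a longer chain such as propyl stays as low as ethyl or whether the low number is confined to ethyl. Also open, on these data alone, is how a pyridyl ring or an amine on this carbon compares with phenyl and methyl.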